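The compounds below may be only part of what the source reports. "The series", "measured", "known", "first", "only" and "open" are said of these compounds alone.

Of the compounds shown here, three of one series have been measured in an ADME assay on RAW264.7 cells (Mus musculus) for cytotoxicity, read by MTT assay, with a stated time of 72 h, tested at 50 uM; a higher number here means more inhibition at the concentration tested (going by the name of the read-out), a lower number less inhibition. Compound 1 `CCOC(=O)c1sc(-c2ccccc2)nc1N1CCC(NCc2ccc(C(F)(F)F)cc2)CC1` gives 22.7%, compound 2 `CCOC(=O)c1sc(-c2ccncc2)nc1N1CCC(NCc2ccc(F)cc2)CC1` gives 17.5%, and compound 3 `CCOC(=O)c1sc(-c2ccncc2)nc1N1CCC(NCc2ccc(OCc3ccccc3)cc2)CC1` gives 8.04%. Compound 3 has the lowest of the three numbers; the nearest is compound 2, and the step of a number 9.5 percentage points lower from compound 2 to compound 3 (within the scatter) lies within the scatter, while the gap to compound 1 is beyond it. Compound 4 `CCOC(=O)c1sc(-c2ccncc2)nc1N1CCC(NCc2ccc(C(F)(F)F)cc2)CC1` differs from compound 3 by trifluoromethyl in place of benzyloxy on an aromatic carbon. For the measured compounds named here, no measured step covers this exchange directly; the only related step, a number 9.5 percentage points lower from compound 2 to compound 3 (within the scatter), was small, and compound 1, which also carries trifluoromethyl, gave 22.7%. Compound 4 is therefore expected to land in a similar region, with a step of a number 8 percentage points higher from compound 3 to compound 4 (within the scatter) from compound 3. The estimate for compound 4 is 16%, with a range from 6% to 28%.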

Compound 4, a percentage reported as inhibition, at one concentration (the size of the read-out at that concentration, not a potency): 18.1%
Compound 4: middle estimate off by 2.1 percentage points, on the low side, within the range that was stated.
By their numbers in this assay, from the lowest: compounds 3, 2, 4 and 1 (each within the scatter of the next, the first and the last beyond it).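

For the compounds shown here, at this position, on an aromatic carbon para to a large group, trifluoromethyl in place of benzyloxy gives the first step beyond the scatter in this assay (a number 10.1 percentage points higher from compound 3 to compound 4 (beyond the scatter)), though only modestly, while trifluoromethyl in place of fluoro stays within it (a number 0.6 percentage points higher from compound 2 to compound 4 (within the scatter)). Pyridin-4-yl in place of phenyl also stays within the scatter (a number 4.6 percentage points lower from compound 1 to compound 4 (within the scatter)). No measurement given here explains these steps. As far as these compounds go, it remains open how a primary amine or a carboxylic acid at this aromatic carbon would read in this assay.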